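This account rests on a few compounds, and the source may have more. Where it says the series, first, only, none or still open, it means among the compounds named here.

Three measured compounds share one core, each carrying an aryl carbonyl on the ring nitrogen. Compound 1 `Cc1ccc(-c2nn(-c3ccccc3)cc2-c2nc3ccccc3n2C(=O)c2ccccc2C)cc1` gives, in an ADME assay on HEK-293T cells (Homo sapiens) for cytotoxicity, read by MTT assay, with a stated time of 24 h (on this read-out higher numbers stand for lower toxicity in this test and lower numbers for higher toxicity in this test), 176000 nM. Compound 2 `Cc1ccccc1C(=O)n1c(-c2cn(-c3ccccc3)nc2-c2ccc(F)cc2)nc2ccccc21` gives in this assay 189000 nM, and compound 3 `O=C(c1ccc(Cl)cc1)n1c(-c2cn(-c3ccccc3)nc2-c2ccc(C(F)(F)F)cc2)nc2ccccc21` gives in this assay 181000 nM. Compound 1 thus stands within the scatter of both compound 2 and compound 3, and the three numbers cannot be told apart. Among the measured compounds shown here, the only step between two compounds that differ in one place, a 1.1-fold higher number from compound 1 to compound 2 (0.03 log units; within the scatter), changes a substituent far from the carbonyl and leaves the number essentially unmoved.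

Compound 4 `Cc1ccc(-c2nn(-c3ccccc3)cc2-c2nc3ccccc3n2C(=O)c2cncc(C)c2)cc1` is not yet measured. It differs from compound 1 as follows: 5-methylpyridin-3-yl in place of 2-methylphenyl on a carbonyl carbon. No measured step exchanges the ring on the carbonyl carbon, so nothing shown bears directly on this change; the nearest guidance is that every alteration so far, including the chloro and trifluoromethyl variant in compound 3, has left this assay flat. On that basis the expected step of a 1.0-fold higher number from compound 1 to compound 4 (0.01 log units; within the scatter) is none beyond the scatter. Compound 4 is therefore expected to give 180000 nM in this assay, with a range from 100000 nM to 320000 nM.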

Compound 4, half-maximal cytotoxic concentration: 155000 nM
Compound 4: middle estimate off by 1.2-fold (0.06 log units), on the high side; the range from low to high includes it.
By their numbers in this assay, from the lowest: compounds 4, 1, 3 and 2 (each within the scatter of the next).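

Among the compounds shown here, at the carbonyl carbon, a single change can now be read for the first time: in this assay 5-methylpyridin-3-yl in place of 2-methylphenyl gives a 1.1-fold lower number from compound 1 to compound 4 (0.06 log units; within the scatter) and so stays inside the usual spread of repeats. The entering ring brings a ring nitrogen and a hydrogen-bond acceptor that the leaving ring lacks, with the same number of heavy atoms and no net charge, and this exchange of ring type does not separate the two compounds in this test. No measurement shown here accounts for this outcome or connects it to any property of either ring.

For the compounds shown here, compounds 1 and 4 give only one exchange at this position, and they cannot separate the added ring nitrogen from the altered placement of the methyl group, since both change together in the step. It remains open whether an amine or a carboxylic acid on this ring, or a longer alkyl chain in place of the ring, would move the number beyond the scatter in this assay or leave it as flat as the four compounds shown.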